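The source may hold more compounds than are shown below. What is called first, only, known or untested is meant among the compounds shown, and "the series" means these compounds.

Measured compounds:
- compound 1 `COc1ccc(C(=O)Nc2cccc(F)c2)cc1Nc1nccc(-c2cccnc2)n1` — in a functional assay on K562 cells (Homo sapiens) for antiproliferative activity, read by MTT assay, with a stated time of 48 h (on this read-out higher numbers stand for weaker inhibition and lower numbers for stronger inhibition), compound 1 gives "not determined" (no result reported)
- compound 2 `COc1ccc(C(=O)Nc2ncccn2)cc1Nc1nccc(-c2cccnc2)n1` — in this assay compound 2 gives "not determined" (no result reported)
- compound 3 `COc1cccc(NC(=O)c2ccc(OC)c(Nc3nccc(-c4cccnc4)n3)c2)c1` — in this assay compound 3 gives 93100 nM

Compound 2 stands without a number in this assay, and compound 1 is in the same position, so the only measured point among these three is compound 3, whose value is very weak. Compound 4 `COc1ccc(C(=O)Nc2ccncc2)cc1Nc1nccc(-c2cccnc2)n1` is the unmeasured member. It differs from compound 2 in one place: pyridin-4-yl in place of pyrimidin-2-yl on an amide-type nitrogen. For the measured compounds named here, no measured pair with a single change is available, so the size of this step cannot be read from the data. Both compounds keep the shared core and the amide seen in compound 3, which is the only anchor for an expectation. The change swaps one six-membered aromatic ring for another on the amide nitrogen; such a swap would be expected to move the number by at most a modest amount in either direction, with no firm direction known. Compound 4 is therefore estimated to lie near the weak level of compound 3, at 60000 nM with a range from 12000 nM to 200000 nM.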

Compound 4, half-maximal inhibitory concentration: 94500 nM
Compound 4: middle estimate off by 1.6-fold (0.20 log units), on the low side, and the stated range covers the measured number.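

In this assay, the amide-type nitrogen now has its first readable comparison: pyridin-4-yl in place of 3-methoxyphenyl gives a 1.0-fold higher number from compound 3 to compound 4 (0.01 log units; within the scatter), so these two aromatic rings cannot be told apart here, and both compounds stay at a very weak level. The swap of pyrimidin-2-yl for pyridin-4-yl cannot be read as a step, as compound 2 has no number to compare with. Nothing in the available data explains why this change leaves the number where it is.

As far as these compounds go, two aromatic rings say little about what else this nitrogen might carry, so it remains open whether a non-aromatic group, such as a short alkyl chain or a piperidine ring, would give a different number. A carboxylic acid or an amine on the pyridin-4-yl ring is equally untested by the compounds shown.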